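The compounds below may be only part of what the source reports. "The series", "measured", "known", "first", "only" and "open" are said of these compounds alone.

Compound 1 `Cn1c(=O)c(=O)n(C2CCCC2)c2nc(N/N=C/c3ccc(S(C)(=O)=O)cc3)ncc21`: 86600 nM
Compound 2 `COc1ccc(/C=N/Nc2ncc3c(n2)n(C2CCCC2)c(=O)c(=O)n3C)cc1`: 36100 nM

Among the measured compounds shown here, in a functional assay on HCT-116 cells (Homo sapiens) for antiproliferative activity, read by MTT assay (on this read-out higher numbers stand for weaker inhibition and lower numbers for stronger inhibition), compound 2 gives 36100 nM, the lower of the two numbers measured so far. The next step leads to compound 3 `Cn1c(=O)c(=O)n(C2CCCC2)c2nc(N/N=C/c3ccc(OC(F)(F)F)cc3)ncc21`, and the change is trifluoromethyl in place of methyl on an oxygen on an aromatic ring, or methoxy to trifluoromethoxy. For the measured compounds named here, only one measured step bears on it, a 2.4-fold lower number from compound 1 to compound 2 (0.38 log units; beyond the scatter). That step is modest, though beyond the scatter, and it is a different exchange, methoxy in place of methylsulfonyl on an aromatic carbon. It gives no firm direction for the new change, so no step beyond the scatter is expected. The expected change is a 1.1-fold higher number from compound 2 to compound 3 (0.04 log units; within the scatter). For compound 3 the estimated value is 40000 nM, with an expected range from 14000 nM to 90000 nM.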

Compound 3, half-maximal inhibitory concentration: 6150 nM
For compound 3 the middle estimate is 6.5-fold (0.81 log units) above the measured one; the measured number lies below the stated range.
By their numbers in this assay, from the lowest: compound 3; then compound 2; then compound 1.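

In this assay the group on the oxygen on the aromatic ring proves to matter: trifluoromethyl in place of methyl gives a 5.9-fold lower number from compound 2 to compound 3 (0.77 log units; beyond the scatter), a step that the earlier pair, which compared only methoxy with methylsulfonyl, could not show. Set against the methylsulfonyl group, trifluoromethoxy gives a 14-fold lower number from compound 1 to compound 3 (1.15 log units; beyond the scatter), so among the three compounds the substituent at this place spans a large range, and trifluoromethoxy gives the lowest number. Nothing given here accounts for the size of this shift.

The compounds shown leave open how a chlorine atom, a nitrile or an amine would read in place of trifluoromethoxy. They also leave open whether the step from methoxy to trifluoromethoxy would hold if another part of the shared core were changed.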